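The source may hold more compounds than are shown below. What is called first, only, known or untested is meant among the compounds shown, and "the series" means these compounds.

Notes on a short series of esters tested in an assay on membranes from HEK293 cells for displacement of a labelled ligand from adenosine receptor A2b (Homo sapiens), read by scintillation counting, with a stated time of 30 min, tested at 1 uM; on this read-out lower numbers stand for less inhibition and higher numbers for more inhibition at the one concentration tested (going by the name of the read-out). Compound 1 `CC1=C(C(=O)OC(C)(C)C)C(c2ccsc2)NC(=S)N1` gives 26% in this assay. Compound 2 `CC1=C(C(=O)OCc2ccccc2)C(c2ccsc2)NC(=S)N1` differs from compound 1 only by benzyl in place of tert-butyl on an oxygen next to a carbonyl group; in this assay compound 2 gives 10%, and the change produced a number 16 percentage points lower from compound 1 to compound 2 (beyond the scatter).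

Compound 3 `CC1=C(C(=O)OC(C)(C)C)C(c2ccco2)NC(=O)N1C` carries a different core; the difference between the two cores is not broken down here. In this assay compound 3 gives 26%, which sits level with compound 1 at the digits given and within the scatter of it.

Compound 4 `CC1=C(C(=O)OCc2ccccc2)C(c2ccco2)NC(=O)N1C` has not yet been measured. It differs from compound 3 by benzyl in place of tert-butyl on an oxygen next to a carbonyl group, the same change as that made from compound 1 to compound 2, at a place described in the same words, so it is treated as the same change. The change has been seen only once before, so the expectation rests on a single step. From that precedent, which gave a number 16 percentage points lower from compound 1 to compound 2 (beyond the scatter), the step is expected to be a number 15 percentage points lower from compound 3 to compound 4 (beyond the scatter). Compound 4 is therefore estimated at 11% in this assay, with a likely range from 0% to 24%.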

Compound 4, a percentage reported as inhibition, at one concentration (the size of the read-out at that concentration, not a potency): 41%
Beside the measured number, compound 4's estimate is 30 percentage points below it, outside the stated range (above it).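

In this assay, benzyl in place of tert-butyl on an oxygen next to a carbonyl group gives a number 15 percentage points higher from compound 3 to compound 4 (beyond the scatter). Set beside the earlier step, the change does not carry from one core to the other in this series, not even in direction: the same change on two cores in this assay, a number 16 percentage points lower (beyond the scatter) from compound 1 to compound 2 and a number 15 percentage points higher (beyond the scatter) from compound 3 to compound 4, 31 percentage points apart, beyond the scatter of two such steps

This does not show which part of the two cores goes with the reversal, since that difference is not broken down, and with a single pair on each core it gives no rule for any further core.

The compounds shown carry only tert-butyl and benzyl on this oxygen, so it remains open how a smaller group such as methyl or ethyl, or a longer chain, would read on either core. Also open, from the compounds shown here alone, is whether a benzyl ring bearing a chlorine or a methoxy group would follow the step seen on the core of compound 1 or the one seen on the core of compound 3.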